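The compounds below may be only part of what the source reports. "The series", "measured", "known", "first", "only" and "open" are said of these compounds alone.

Compound 1 `Cc1ccc(C2CC(c3ccccc3)=NN2C(=O)c2cc3ccccc3o2)cc1`: 16.6 ug/mL
Compound 2 `O=C(c1cc2ccccc2o1)N1N=C(c2ccccc2)CC1c1ccc([N+](=O)[O-])cc1`: 4.87 ug/mL
Compound 3 `O=C(c1cc2ccccc2o1)N1N=C(c2ccccc2)CC1c1ccc(F)cc1`: 9.94 ug/mL

These three compounds were tested in a functional assay on A2780 cells (Homo sapiens) for antiproliferative activity, read by MTT assay, with a stated time of 72 h (a higher number here means a weaker inhibitor, a lower number a stronger inhibitor), and compound 1 stands at the high end of their numbers. There is a 1.7-fold lower number from compound 1 to compound 3 (0.22 log units; within the scatter), whereas there is also a 3.4-fold lower number from compound 1 to compound 2 (0.53 log units; beyond the scatter). Compound 1 is therefore separated clearly from only one of the other two.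

Compound 4 `COc1ccc(C2CC(c3ccccc3)=NN2C(=O)c2cc3ccccc3o2)cc1` keeps the core of compound 1 and differs from it in one place, with methoxy in place of methyl on an aromatic carbon.

Going by the values given here, no methoxy compound has been measured, so the evidence is indirect. The two measured replacements of methyl at this place are the steps already given, one within the scatter and one modest. The remaining measured step, a 2.0-fold higher number from compound 2 to compound 3 (0.31 log units; beyond the scatter), is also modest. None of the three is large, so only a small step is expected in this assay, most likely within the scatter and slightly towards a lower number. The expected outcome is a 1.4-fold lower number from compound 1 to compound 4 (0.14 log units; within the scatter). For compound 4 the estimated value is 12 ug/mL. The expected range for compound 4 runs from 5.5 ug/mL to 26 ug/mL.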

Compound 4, half-maximal inhibitory concentration: 4.57 ug/mL
Compound 4: the middle estimate sits 2.6-fold (0.42 log units) above what was measured; the measured number lies below the stated range.
By their numbers in this assay, from the lowest: compounds 4 and 2 (each within the scatter of the next); then compounds 3 and 1 (each within the scatter of the next).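

Methoxy at this place, para to a large group, gives a 3.6-fold lower number from compound 1 to compound 4 (0.56 log units; beyond the scatter) in this assay, so nitro is no longer the only replacement of methyl shown to move the number beyond the scatter, while fluoro remains the one replacement that does not. The change from 4-methylphenyl to 4-methoxyphenyl also separates compound 4 from the fluoro analogue, with a 2.2-fold lower number from compound 3 to compound 4 (0.34 log units; beyond the scatter), yet there is only a 1.1-fold lower number from compound 2 to compound 4 (0.03 log units; within the scatter), so methoxy and nitro cannot be told apart here and the four compounds fall into two pairs, compounds 2 and 4 on one side and compounds 1 and 3 on the other. Nothing measured here bears on why methoxy and nitro should match each other in this assay.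

The compounds shown leave open whether a hydroxyl, an amine or a longer chain such as ethoxy on the same aromatic carbon would stay with compounds 2 and 4 or fall back towards compounds 1 and 3. They also leave open whether a methoxy group elsewhere on this ring, or on the unchanged phenyl group of the shared core, would give a similar step in this assay.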